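The compounds below may be only part of what the source reports. "The series", "measured", "known", "first", "only" and "open" are said of these compounds alone.

Measured compounds:
compound 1 `COc1ccc(NC(=O)CSc2nc3cc(Br)cnc3[nH]2)cc1OC` gives 192 nM in an assay on isolated protein for inhibition of Ectonucleotide pyrophosphatase/phosphodiesterase family member 1 (Homo sapiens), using Lineweaver-Burk analysis; a higher number here means a weaker inhibitor, a lower number a stronger inhibitor
compound 2 `COc1ccc(NC(=O)CSc2nc3c(N)nc(SC)nc3[nH]2)cc1OC` gives 152 nM in this assay

The two measured compounds lie within the usual scatter of each other, so compound 1 does not stand apart from compound 2 on these numbers. Compound 3 `COc1ccc(NC(=O)CSc2nc3cc(Cl)cnc3[nH]2)cc1OC` differs from compound 1 in one place: chloro in place of bromo on an aromatic carbon. Among the compounds with values here, no measured pair shows this kind of change here, so the expected step from compound 1 to compound 3 in this assay is estimated small, a 1.2-fold higher number from compound 1 to compound 3 (0.08 log units; within the scatter), possibly a little weaker, and not clearly beyond the scatter. Compound 3 is therefore expected to give about 230 nM, within a range of 110 nM to 480 nM.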

Compound 3, inhibition constant: 137 nM
Estimate against measurement, compound 3: 1.7-fold (0.23 log units) above; the measured number falls inside the stated range.
By their numbers in this assay, from the lowest: compounds 3, 2 and 1 (each within the scatter of the next).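

Within the data shown here, replacing bromo with chloro on this aromatic carbon gives the first comparison in this assay of two compounds that differ in one place: a 1.4-fold lower number from compound 1 to compound 3 (0.15 log units; within the scatter). At this position, the two halogens cannot be told apart on these numbers, so the inhibition seen with compound 1 does not depend on bromo specifically. No measurement shown bears on why the two compounds read alike.

Going by these compounds, whether this carbon tolerates only halogens remains open. A plain hydrogen, a methyl group or an amine in the same place could show how much the position matters.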